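Cyclohexyl to hydrogen: cytotoxicity notes at the assay limit

A few compounds are considered here, and "the series" means these few. Any claim that something is new, unique, unknown or untested is made for them only; others in the source may bear on it.

Of the compounds shown here, two have been tested in an ADME assay on MDBK cells (Bos taurus) for cytotoxicity, read by MTT assay, with a stated time of 96 h; a lower number here means that less compound is tolerated, a higher number that more compound is tolerated. Compound 1 (`CC(=O)c1ccc2[nH]c(-c3ccoc3)nc2c1`) gives only a limit, >= 100000 nM. Compound 2 (`C/C(=N\NC(N)=O)c1ccc2c(c1)nc(-c1ccoc1)n2C1CCCCC1`) likewise gives only a limit, > 100000 nM. Its standing is therefore known as a limit and not as a number, and no half-maximal cytotoxic concentration has yet been resolved in the series.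

Compound 3 (`C/C(=N\NC(N)=O)c1ccc2[nH]c(-c3ccoc3)nc2c1`) differs from compound 2 in one place: hydrogen in place of cyclohexyl on an aromatic nitrogen. In words, hydrogen stands in place of cyclohexyl on an aromatic nitrogen. For the measured compounds named here, no measured pair shows the size of such a change in this assay, so the expectation rests on limits alone. It rests first on compound 2, with its limit of > 100000 nM. It rests also on compound 1, with its limit of >= 100000 nM.

The expected outcome, a number no higher from compound 2 to compound 3 (the limit leaves the size open), is no step beyond the usual scatter, in either direction. A further limit is the most likely report. Compound 3 is estimated at 100000 nM, with an expected range of 45000 nM to 100000 nM.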

Compound 3, half-maximal cytotoxic concentration: > 100000 nM
Compound 3: a limit, no number (the forecaster's own chance of this, stated with the estimate: 85%); the middle value lies on the limit itself.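

In this assay compound 3 gives > 100000 nM, a limit and not a number. For the compounds shown here, no step can therefore be read, neither between compound 2 and compound 3 nor between compound 1 and compound 3. The compounds shown leave open where any half-maximal cytotoxic concentration lies, and whether hydrogen in place of cyclohexyl changes it at all.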